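Adding a tert-Butyl Group to a Thiazole Amide

The compounds below may be only part of what the source reports. "The series", "measured", "known", "first", "only" and "open" are said of these compounds alone.

Measured compounds:
compound 1 `N#Cc1cc(F)cc(C(=O)Nc2cccnc2)c1`: > 30000 nM
compound 2 `N#Cc1cc(F)cc(C(=O)Nc2nccs2)c1`: > 10000 nM

Compound 1 `N#Cc1cc(F)cc(C(=O)Nc2cccnc2)c1` was tested in an in vitro functional assay on HEK293-A cells for antagonist activity at metabotropic glutamate receptor 5 (Rattus norvegicus), read by calcium flux; on this read-out higher numbers stand for weaker inhibition and lower numbers for stronger inhibition. For compound 1 the value > 30000 nM is a limit of the assay and not a number. Compound 2 `N#Cc1cc(F)cc(C(=O)Nc2nccs2)c1` carries 1,3-thiazol-2-yl in place of pyridin-3-yl on an amide-type nitrogen. In this assay compound 2 also gives only a limit, > 10000 nM. The step that the two limits leave unreadable from compound 1 to compound 2 therefore cannot be sized. Compound 2 stands at the limit of > 10000 nM in this assay, at which 1 of the 2 values shown sits, while the other value sits at the limit of > 30000 nM in this assay, at which 1 of the 2 values shown sits.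

Compound 3 `CC(C)(C)c1csc(NC(=O)c2cc(F)cc(C#N)c2)n1` differs from compound 2 by tert-butyl in place of hydrogen on an aromatic carbon. Among the compounds with values here, no measured step touches an aromatic carbon in this way, and the only step on record, a step that the two limits leave unreadable from compound 1 to compound 2, is unreadable, so no measured step sets the size or direction of the change expected in this assay. Compound 3 is estimated at 3000 nM, with a range from 300 nM to 30000 nM. This estimate means an expected step of an at least 3.3-fold lower number from compound 2 to compound 3 (0.52 log units; beyond the scatter), with a real chance that only a limit is reported once more.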

Compound 3, half-maximal inhibitory concentration: > 10000 nM
Compound 3 gave a limit, no number; the forecaster's own chance of this, stated with the estimate: 40%; middle value at least 3.3-fold (0.52 log units) away from the limit.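

In this assay compound 3 gives > 10000 nM, a limit of the assay and not a number. Compound 2 gives > 10000 nM, also only a limit, so the step between these two compounds cannot be read. The compounds shown leave open whether tert-butyl in place of hydrogen on an aromatic carbon changes inhibition at all, and how compound 1, compound 2 and compound 3 rank against one another.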